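The compounds below may be only part of what the source reports. "The series", "measured", "known", "first", "only" and "open" are said of these compounds alone.

Measured compounds in an assay on isolated protein for inhibition of dual specificity protein kinase CLK2 (Homo sapiens), read by scintillation counting and 33P incorporation, with a stated time of 40 min, in the presence of a further agent that is not named here; a lower number here means a stronger inhibitor, a higher number a weaker inhibitor:
compound 1 `CC(=O)Nc1cc(Cl)cc(Nc2nc(N[C@@H]3CCCC[C@@H]3N)nc3c2ncn3C(C)C)c1`: 7 nM; 13 nM (2 entries)
compound 2 `CC(=O)Nc1cc(Cl)cc(Nc2nc(N[C@H]3CCCC[C@H]3N)nc3c2ncn3C(C)C)c1`: 17 nM
compound 3 `CC(C)n1cnc2c(Nc3cc(N)cc(Cl)c3)nc(N[C@H]3CCNC3)nc21`: 28 nM

Compound 3 stands at 28 nM in this assay. The nearest single number comes from compound 2 at 17 nM, and the gap between the two lies within the scatter; compound 1 contributes several entries rather than one number (the several entries of compound 1 in this assay, 7 nM; 13 nM (2 entries)).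

The step from compound 3 to compound 4 `CC(C)n1cnc2c(Nc3cc(N)cc(Cl)c3)nc(N[C@@H]3CCNC3)nc21` is a change of configuration alone: the two compounds have the same atoms and bonds and differ only in configuration as drawn: 1 of 1 stereo elements differ; a stereocentre at a saturated ring carbon is drawn S in compound 3 and R in compound 4. Among the compounds with values here, no such step between two measured compounds is recorded in this assay for the pyrrolidine, but the pair of compound 1 and compound 2 offers a related case, because of the fact that compounds 1 and 2 differ only in the configuration as drawn, and their numbers sit within the scatter of each other. On that basis no step beyond the scatter is expected here in either direction, though the pyrrolidine case rests on a single precedent.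

Compound 4 is therefore expected near 30 nM, with a range of 10 nM to 100 nM. The expected step of a 1.1-fold higher number from compound 3 to compound 4 (0.03 log units; within the scatter) is estimated to stay within the scatter.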

Compound 4, half-maximal inhibitory concentration: 92 nM
The estimate for compound 4 lay 3.1-fold (0.49 log units) below the measured number; the measured number falls inside the stated range.
By their numbers in this assay, from the lowest: compounds 2 and 3 (each within the scatter of the next); then compound 4.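

In this assay, the change of the stereocentre at a saturated ring carbon from S to R gives a 3.3-fold higher number from compound 3 to compound 4 (0.52 log units; beyond the scatter), so the S form as drawn has the lower number in this pair. The earlier pair with a configurational difference did not show a step this clear, with compound 1 at 7 nM; 13 nM (2 entries) and compound 2 at 17 nM. The pair of compound 3 and compound 4 therefore shows that configuration alone can move the number in this series, with no other structural change involved: the fact that compounds 3 and 4 differ only in the configuration as drawn.

From the compounds shown here alone, whether the S form keeps its lower number with a methyl group on the ring nitrogen, or with a piperidine in place of the pyrrolidine, remains open. Within the data shown here, only this single pair speaks for the pyrrolidine, so the size of the step has no second example.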